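The source may hold more compounds than are shown below. What is called first, only, known or untested is meant among the compounds shown, and "the series" means these compounds.

Measured so far:
- compound 1, `COc1cc(Br)cc(/C=C/C(=O)c2ccc(Cl)cc2)c1O`: 53.3%
- compound 2, `COc1cccc(C(=O)/C=C/c2cc(Br)ccc2O)c1`: 26.9%

In a functional assay on MCF7 cells (Homo sapiens) for antiproliferative activity, read by sulforhodamine B assay, with a stated time of 72 h, tested at 10 uM (a higher number here means a weaker effect of the compound at the concentration tested, a lower number a stronger effect), compound 1 gives 53.3%, the higher of the two numbers recorded. Compound 2 gives 26.9% in this assay, a lower reading, and the gap between the two readings lies beyond the usual scatter, so compound 1 shows the weaker effect of the two at the tested concentration. The two compounds differ in more than one place, so no single step can be read from them.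

Compound 3, `COc1cc(Br)cc(/C=C/C(=O)c2ccc(Br)cc2)c1O`, is not yet measured. It differs from compound 1 by bromo in place of chloro on an aromatic carbon. The change is one halogen for another of the same kind of position on the same ring. Among the compounds with values here, no measured pair shows this exchange. The step of a number 3.3 percentage points lower from compound 1 to compound 3 (within the scatter) is expected to be small, in no clear direction, and within the scatter. Compound 3 is estimated to give 50% in this assay, with a range from 35% to 65%.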

Compound 3, a percentage reported as activity, at one concentration (the size of the read-out at that concentration, not a potency): 64.6%
Compound 3: the middle estimate sits 14.6 percentage points below what was measured; low and high end bracket the measured number.
By their numbers in this assay, from the lowest: compound 2; then compound 1; then compound 3.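

In this assay, the site on the 4-chlorophenyl ring proves sensitive to which halogen it carries: bromo in place of chloro gives a number 11.3 percentage points higher from compound 1 to compound 3 (beyond the scatter), a modest weakening of the effect at the tested concentration. Within the data shown here, this is the first single-place step, and it shows that exchanging one halogen for another on an aromatic carbon, with no change in rings, hydrogen-bond donors or acceptors, or net charge, can move the reading beyond the scatter. Nothing at hand accounts for this step.

As far as these compounds go, only chloro and bromo are compared at this position, so it remains open how fluoro, methoxy, an amine or a carboxylic acid would read there. A single pair also leaves open whether the same step would hold on a different core, and compound 2 differs from compound 1 in more than one place, so it cannot answer this.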